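A few compounds are considered here, and "the series" means these few. Any claim that something is new, unique, unknown or untested is made for them only; others in the source may bear on it.

Measured compounds:
Compound 1, `CCN(CC)C(=O)C1=C(C)NC(=O)NC1c1cccs1`: 31% in an assay on membranes from HeLa cells for displacement of a labelled ligand from adenosine receptor A3 (Homo sapiens), read by scintillation counting, with a stated time of 180 min, tested at 1 uM; on this read-out higher numbers stand for more inhibition at the one concentration tested (going by the name of the read-out) and lower numbers for less inhibition
Compound 2, `CCC(C)OC(=O)C1=C(C)NC(=O)NC1c1cccs1`: 7% in this assay

Within the data shown here, compound 2 stands lowest of the two numbers in this assay; its only neighbour is compound 1, which lies higher by a margin beyond the scatter. Among the measured compounds shown here, the single measured step, a number 24 percentage points lower from compound 1 to compound 2 (beyond the scatter), concerns the exchange of diethylamino for sec-butoxy on the carbonyl carbon. Compound 3, `CC1=C(C(=O)OC2CCCCC2)C(c2cccs2)NC(=O)N1`, has not yet been measured. It differs from compound 2 in one place: cyclohexyl in place of sec-butyl on an oxygen next to a carbonyl group. For the measured compounds named here, no measured step alters the alkyl part of the ester, so this change has no direct precedent among the two compounds; the one known step bears on a different position and gives no guide to its direction. For compound 3 a step of a number 3 percentage points higher from compound 2 to compound 3 (within the scatter) is therefore expected, which is to say none beyond the scatter. Compound 3 is estimated at 10%, within the range 0% to 30%.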

Compound 3, a percentage reported as inhibition, at one concentration (the size of the read-out at that concentration, not a potency): 1%
Estimate against measurement, compound 3: 9 percentage points above; low and high end bracket the measured number.
By their numbers in this assay, from the lowest: compounds 3 and 2 (each within the scatter of the next); then compound 1.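

In this assay, cyclohexyl in place of sec-butyl on an oxygen next to a carbonyl group gives a number 6 percentage points lower from compound 2 to compound 3 (within the scatter), so adding a six-membered ring to the ester alkyl group leaves the two esters indistinguishable. Cyclohexyloxy in place of diethylamino on a carbonyl carbon gives a number 30 percentage points lower from compound 1 to compound 3 (beyond the scatter), which shows that the gap first seen in a number 24 percentage points lower from compound 1 to compound 2 (beyond the scatter) is not confined to a single ester; among these three compounds, none goes against this. No evidence is available to explain why the diethylamino compound stands apart from the two esters.

As far as these compounds go, it remains open whether a methyl or ethyl ester, or a free carboxylic acid, would fall with the two esters. From the compounds shown here alone, it is equally open whether an amide of another amine, such as pyrrolidine or dimethylamine, would match compound 1.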